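A few compounds are considered here, and "the series" means these few. Any claim that something is new, unique, unknown or untested is made for them only; others in the source may bear on it.

In a functional assay on DLD-1 cells (Homo sapiens) for antiproliferative activity, read by CellTiter-Glo, with a stated time of 72 h (on this read-out lower numbers stand for stronger inhibition and higher numbers for weaker inhibition), compound 1 `Cc1noc(C)c1S(=O)(=O)N1CCC(N2CCC(C)CC2)CC1` gives only a limit of the assay, > 5000 nM. Compound 3 `Cc1cc(C)c(S(=O)(=O)N2CCC(c3ccccc3)CC2)c(C)c1` likewise returns only a limit in this assay, > 5000 nM. Going by the values given here, compound 2 `COc1ccccc1-c1cccc(S(=O)(=O)N2CCC(N3CCC(C)CC3)CC2)c1` is the single member with a number, 21 nM in this assay, and it carries a larger biaryl group on the sulfonyl sulfur than either of the others. Among the compounds with values here, no measured step between two compounds differing in one place is available. Compound 4 `CC1CCN(C2CCN(S(=O)(=O)c3cccnc3F)CC2)CC1` differs from compound 1 by 2-fluoropyridin-3-yl in place of 3,5-dimethyl-1,2-oxazol-4-yl on a sulfonyl sulfur. Both groups are small aromatics of the same heavy-atom count, and with compound 1 at the limit of > 5000 nM in this assay, at which 2 of the 3 values shown sit, the step of an at least 1.2-fold lower number from compound 1 to compound 4 (0.09 log units; that floor lies within the scatter) is expected to stay within the scatter rather than reach the range of compound 2. Compound 4 is therefore estimated at 4000 nM, between 800 nM and 20000 nM in this assay.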

Compound 4, half-maximal inhibitory concentration: > 5000 nM
Compound 4: no number, only a limit (the forecaster's own chance of this, stated with the estimate: 55%); middle value at least 1.2-fold (0.09 log units) away from the limit.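

Compound 1 and compound 4 both return only a limit, so no step between them can be read: the limit of > 5000 nM in this assay, at which 3 of the 4 values shown sit.

Still open, going by these compounds, is whether 2-fluoropyridin-3-yl and 3,5-dimethyl-1,2-oxazol-4-yl on a sulfonyl sulfur differ at all in activity.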